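A few compounds are considered here, and "the series" means these few. Any claim that something is new, unique, unknown or untested is made for them only; others in the source may bear on it.

Compound 1 `CCOC(=O)COc1cc(-c2cc(=O)c3c(O)cc(OCC(=O)N4CCN(Cc5ccc(OC)cc5)CC4)cc3o2)ccc1OC` carries the shared core of this small series. In an ADME assay on MRC5 cells (Homo sapiens) for cytotoxicity (a higher number here means a weaker inhibitor, a lower number a stronger inhibitor), compound 1 is recorded as "not determined" (no result reported), so no single number exists for it. Two related compounds give a bearing on where the series sits. Compound 2 `CCOC(=O)COc1cc(-c2cc(=O)c3c(O)cc(OCC(=O)N4CCN(Cc5c(OC)cc(OC)cc5OC)CC4)cc3o2)ccc1OC` in this assay gives 9500 nM, and compound 3 `CCOC(=O)COc1cc(-c2cc(=O)c3c(O)cc(OCC(=O)N4CCN(Cc5ccc(OCc6ccccc6)c(OC)c5OC)CC4)cc3o2)ccc1OC` in this assay gives 10000 nM. These two values lie within the usual scatter of each other, so nothing separates them. Compound 4 `CCOC(=O)COc1cc(-c2cc(=O)c3c(O)cc(OCC(=O)N4CCN(C(=O)OC(C)(C)C)CC4)cc3o2)ccc1OC` is the compound still to be measured. It differs from compound 1 in one place: tert-butoxycarbonyl in place of 4-methoxybenzyl on an amine nitrogen in a ring. Among the compounds with values here, no measured pair covers this exchange, so the expectation rests only on what compound 2 and compound 3 show, and the step is expected to stay within the scatter, with no direction to favour. Compound 4 is therefore estimated to reach about 10000 nM in this assay, within a range from 3500 nM to 30000 nM.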

Compound 4, half-maximal inhibitory concentration: 3800 nM
Compound 4: middle estimate off by 2.6-fold (0.42 log units), on the high side; the range from low to high includes it.
By their numbers in this assay, from the lowest: compound 4; then compounds 2 and 3 (each within the scatter of the next).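

In this assay, within the data shown here, compound 1 has no single number, so no step to compound 4 can be read from the exchange of 4-methoxybenzyl for tert-butoxycarbonyl. What that exchange does to the value therefore stays open, and nothing shown here offers an explanation for the result of compound 4.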